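Removing a chlorine and lengthening the linker in one step

This account rests on a few compounds, and the source may have more. Where it says the series, first, only, none or still open, it means among the compounds named here.

Measured compounds:
- compound 1, `Clc1cccc2c1CC2CCCN1CCN(c2cccc3c2OCCO3)CC1`: 1100 nM
- compound 2, `Fc1cccc2c1CC2CN1CCN(c2cccc3c2OCCO3)CC1`: 316 nM
- compound 3, `C1=C(CCN2CCN(c3cccc4c3OCCO4)CC2)Cc2ccccc21`: 933 nM

Of the compounds shown here, three sharing the same core have been tested in an assay on isolated protein for binding affinity to 5-hydroxytryptamine receptor 1B (Rattus norvegicus); a lower number here means a stronger inhibitor, a higher number a weaker inhibitor. Compound 1 gives 1100 nM, the highest of the three numbers. Compound 3 gives 933 nM, which lies within the usual scatter of the number for compound 1, so the two cannot be told apart. Compound 2 gives 316 nM, a lower number that lies beyond the scatter relative to compound 1.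

The step followed here leads from compound 1 to compound 4, `c1ccc2c(c1)CC2CCCCN1CCN(c2cccc3c2OCCO3)CC1`, which has not yet been measured. The change is a group of 9 heavy atoms (9 carbon; one four-membered non-aromatic ring of carbon only, one six-membered aromatic ring of carbon only) in place of a group of 9 heavy atoms (8 carbon, 1 chlorine; one four-membered non-aromatic ring of carbon only, one six-membered aromatic ring of carbon only), on a saturated chain carbon, three bonds along the chain from an amine nitrogen in a ring. Within the data shown here, no step between measured compounds matches this change, so there is no direct precedent for its size. The closest comparison is that compounds with other aryl groups and linkers in this set all fall in the same broad region, and none of them differs from compound 1 by a large margin. The step of a 1.4-fold lower number from compound 1 to compound 4 (0.14 log units; within the scatter) is therefore expected to be small, not beyond the scatter, with a slight lean towards a lower number. For compound 4 the estimate in this assay is 800 nM, with a range from 250 nM to 2500 nM.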

Compound 4, inhibition constant: 631 nM
Beside the measured number, compound 4's estimate is 1.3-fold (0.10 log units) above it; the measured number falls inside the stated range.
By their numbers in this assay, from the lowest: compounds 2, 4, 3 and 1 (each within the scatter of the next, the first and the last beyond it).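

In this assay, among these compounds, the step from the chlorine-bearing group to the all-carbon group, a 1.7-fold lower number from compound 1 to compound 4 (0.24 log units; within the scatter), gives the first direct comparison in this set between two compounds that differ in one place. On this reading, the exchange at this saturated chain carbon, three bonds along the chain from an amine nitrogen in a ring, does not separate the two compounds, and the loss of the chlorine and the change in the chain together leave no effect that can be told from the usual scatter of the assay. No measurement bearing on the reason for this result is available here.

The compounds shown hold no pair in which only the chlorine or only the chain changes, so a small net step could reflect two small changes or two larger ones that offset each other, and the single step cannot tell these apart. Going by these compounds, it also stays open whether a methoxy group in place of the chlorine, or an amine or a carboxylic acid at the end of the group, would move the number beyond the scatter.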